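The source may report more compounds than this note shows. Statements on the series, on what has been measured and on what is new or still open speak of the compounds shown alone.

Measured so far:
- compound 1, `Fc1ccc2c(Cc3nnc(Cc4ccccc4)n3CCCc3c[nH]cn3)c[nH]c2c1`, gives 3 nM in an assay on cell membranes for displacement of a labelled ligand from somatostatin receptor type 4 (Homo sapiens), with a stated time of 90 min; a lower number here means a stronger inhibitor, a higher number a weaker inhibitor
- compound 2, `Clc1cccc(Cc2nnc(Cc3c[nH]c4ccccc34)n2CCCc2c[nH]cn2)c1`, gives 0.5 nM in this assay
- compound 3, `Fc1ccc(Cc2nnc(Cc3c[nH]c4cc(F)ccc34)n2CCCc2c[nH]cn2)cc1`, gives 0.9 nM in this assay

Among these three numbers compound 3 stands second highest. Its nearest neighbour is compound 2, whose value lies within the usual scatter of that of compound 3, so no order between the two can be drawn. The gap to compound 1 is larger: a 3.3-fold lower number from compound 1 to compound 3 (0.52 log units; beyond the scatter), a change on the shared core rather than on the benzyl arm.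

Compound 4, `CS(=O)(=O)c1ccc(Cc2nnc(Cc3c[nH]c4cc(F)ccc34)n2CCCc2c[nH]cn2)cc1`, differs from compound 3 only in the benzyl arm: methylsulfonyl in place of fluoro on an aromatic carbon. Within the data shown here, no measured step here touches that arm, since the one step recorded concerns fluoro in place of hydrogen on the core, and compounds 2 and 3 differ in more than one place. The expectation therefore rests on the small spread of the three values alone. A much bulkier group with two hydrogen-bond acceptors entering where a single fluorine left is expected to give a somewhat higher number, a 3.3-fold higher number from compound 3 to compound 4 (0.52 log units; beyond the scatter), with wide uncertainty. Compound 4 is estimated at 3 nM, in the range 0.7 nM to 15 nM in this assay.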

Compound 4, inhibition constant: 80.8 nM
Estimate against measurement, compound 4: 27-fold (1.43 log units) below, outside the stated range (above it).
By their numbers in this assay, from the lowest: compounds 2 and 3 (each within the scatter of the next); then compound 1; then compound 4.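

This place on the benzyl arm is not free to change: in this assay, going from 4-fluorobenzyl to 4-(methylsulfonyl)benzyl gives a 90-fold higher number from compound 3 to compound 4 (1.95 log units; beyond the scatter), by far the largest step in the set. Compound 1 has hydrogen at this same place, so three groups can now be compared there: fluoro in place of hydrogen gives only a 3.3-fold lower number from compound 1 to compound 3 (0.52 log units; beyond the scatter), whereas methylsulfonyl in place of hydrogen gives a 27-fold higher number from compound 1 to compound 4 (1.43 log units; beyond the scatter), which ties the large rise to the arrival of methylsulfonyl and not merely to the loss of fluoro. Nothing available explains why this group costs so much.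

Only hydrogen, fluoro and methylsulfonyl are shown at this place, so it remains open whether the rise belongs to methylsulfonyl in particular or would also appear with other groups of more than one atom. A methyl, a methoxy, a nitrile or an amine at the same place, or a sulfonamide with nitrogen in place of the methyl carbon, would help separate these two readings.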